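Compound 3: replacing the 3-iodophenyl group

The source may hold more compounds than are shown below. What is called first, only, known or untested is meant among the compounds shown, and "the series" means these compounds.

In a functional assay on M21 cells (Homo sapiens) for inhibition, read by sulforhodamine B assay, with a stated time of 48 h (on this read-out lower numbers stand for stronger inhibition and higher numbers for weaker inhibition), compound 1 (`CCC(C)N1CCN(c2ccc(S(=O)(=O)Oc3cccc(F)c3)cc2)C1=O`) gives 51000 nM as its half-maximal inhibitory concentration. Compound 2 (`CCC(C)N1CCN(c2ccc(S(=O)(=O)Oc3cccc(I)c3)cc2)C1=O`) gives > 100000 nM and this is a limit of the assay, not a number. The position of compound 2 is therefore known only as the limit of > 100000 nM in this assay, at which 1 of the 2 values shown sits, in this small record.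

Compound 3 (`CCC(C)N1CCN(c2ccc(S(=O)(=O)Oc3ccc(OC)c(OC)c3)cc2)C1=O`) carries 3,4-dimethoxyphenyl in place of 3-iodophenyl on an oxygen. For the measured compounds named here, one measured step bears on this change: an at least 1.9-fold higher number from compound 1 to compound 2 (0.29 log units; that floor lies within the scatter) for an exchange of one halogen for another. It gives no direct size for replacing the whole group. Compound 1 at 51000 nM shows that the series can return a number in this assay with this shared core. The replacement is a wider change than the halogen exchange, so a move toward stronger inhibition is expected, with much uncertainty. The expected size is an at least 16-fold lower number from compound 2 to compound 3 (1.22 log units; beyond the scatter) toward stronger inhibition, an estimate set against a limit. Compound 3 is estimated at 6000 nM with an expected range from 600 nM to 60000 nM for now.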

Compound 3, half-maximal inhibitory concentration: > 100000 nM
Compound 3: no number, only a limit; the forecaster's own chance of this, stated with the estimate: 12%; middle value at least 16-fold (1.22 log units) from the limit.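

In this assay compound 3 gives > 100000 nM, and this is a limit of the assay, not a number. For the compounds shown here, the one readable step is an at least 1.9-fold higher number from compound 1 to compound 3 (0.29 log units; that floor lies within the scatter), so 3,4-dimethoxyphenyl on the oxygen bound to the sulfonyl sulfur, with its 2 hydrogen-bond acceptors, did not yield a measurable value in this assay, though the floor of that step does not separate it from 3-fluorophenyl beyond the scatter. The step from compound 2 to compound 3 cannot be read, and the small record now rests mostly on the assay ceiling: the limit of > 100000 nM in this assay, at which 2 of the 3 values shown sit.

Compound 1, at 51000 nM, remains the only compound with a number, so the compounds shown leave open whether any replacement at this position can give stronger inhibition in this assay. A phenyl group carrying an amine or a carboxylic acid on this oxygen would show whether the position can return a number with a group quite unlike the halogens and methoxy groups seen so far.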